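The source may report more compounds than this note shows. Statements on the series, on what has been measured and on what is new or still open speak of the compounds shown alone.

Compound 3, with the structure `O=C(C1CC1)N1CCN(Cc2nc3ccccc3n2Cc2ccc(Cl)cc2)CC1`, carries the highest number among the three compounds measured in an assay on isolated protein for inhibition of aldehyde dehydrogenase 1A1 (Homo sapiens), read by spectrophotometry, tested at 10 uM; a lower number here means less inhibition, a higher number more inhibition at the concentration tested (going by the name of the read-out): compound 3 gives 56.6%. Compound 1, `O=C(C1CC1)N1CCN(Cc2nc3ccccc3n2Cc2ccccc2C(F)(F)F)CC1`, gives 56.3% in this assay, and the two numbers lie within the scatter of each other. Compound 2, `O=C(C1CC1)N1CCN(Cc2nc3ccccc3n2Cc2ccc(C(F)(F)F)cc2)CC1`, gives 37% in this assay, and the step of a number 19.6 percentage points higher from compound 2 to compound 3 (beyond the scatter) lies beyond the scatter.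

Compound 4 has the structure `O=C(C1CC1)N1CCN(Cc2nc3ccccc3n2Cc2cccc(Cl)c2)CC1`. Compared with compound 3, the difference is 3-chlorophenyl in place of 4-chlorophenyl on a saturated chain carbon bound to an aromatic nitrogen. The two measured steps that bear on this are the two in which the group on the saturated chain carbon bound to the aromatic nitrogen changes its substitution pattern or its substituent: the step of a number 19.3 percentage points lower from compound 1 to compound 2 (beyond the scatter) and the step of a number 0.3 percentage points higher from compound 1 to compound 3 (within the scatter). One of these moved the number modestly downward, the other stayed within the scatter, so a shift of a chlorine to another position on the same ring is expected to give at most a modest change, more likely downward than upward. The expected step is a number 6.6 percentage points lower from compound 3 to compound 4 (within the scatter). Compound 4 is therefore estimated at 50% in this assay, with a range from 32% to 66%.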

Compound 4, a percentage reported as inhibition, at one concentration (the size of the read-out at that concentration, not a potency): 71.6%
Compound 4: the middle estimate sits 21.6 percentage points below what was measured; the measured number lies above the stated range.
By their numbers in this assay, from the lowest: compound 2; then compounds 1 and 3 (each within the scatter of the next); then compound 4.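

Moving the chlorine alone, with the atoms otherwise unchanged, shifts the number in this assay: the change to 3-chlorophenyl gives a number 15 percentage points higher from compound 3 to compound 4 (beyond the scatter), so the two chlorophenyl groups are not interchangeable on the saturated chain carbon bound to an aromatic nitrogen. Going by these compounds alone, the same group also separates compound 4 from the two trifluoromethyl compounds, with a number 15.3 percentage points higher from compound 1 to compound 4 (beyond the scatter) and a number 34.6 percentage points higher from compound 2 to compound 4 (beyond the scatter), which leaves compound 4 with the highest number of the four and shows that this place can carry more inhibition than the earlier compounds had reached. Nothing available accounts for this difference between the two chlorophenyl groups.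

The compounds shown leave open whether the gain belongs to chloro in particular or would also appear with 3-(trifluoromethyl)phenyl, 3-methoxyphenyl or 3-carboxyphenyl, and how 2-chlorophenyl would read beside its two chlorinated relatives. Since each number comes from a single tested concentration, they also leave open how these differences in inhibition would translate into differences in potency.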